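The source may hold more compounds than are shown below. What is called first, only, known or untested is meant among the compounds shown, and "the series" means these compounds.

Of the compounds shown here, three of one family have been tested in a functional assay on MCF7 cells (Homo sapiens) for antiproliferative activity, read by MTT assay, with a stated time of 48 h; a lower number here means a stronger inhibitor, a higher number a weaker inhibitor. Compound 1 `Clc1cc2nc(-c3cn(-c4ccccc4)nc3-c3ccccc3)[nH]c2cc1Cl` gives 7560 nM in this assay. Compound 2 `Fc1ccc(-c2nn(-c3ccccc3)cc2-c2nc3cc(Cl)c(Cl)cc3[nH]2)cc1` differs from it by fluoro in place of hydrogen on an aromatic carbon; in this assay compound 2 gives 6930 nM, and the step is a 1.1-fold lower number from compound 1 to compound 2 (0.04 log units; within the scatter). Compound 3 `Clc1ccc(-c2nn(-c3ccccc3)cc2-c2nc3ccccc3[nH]2)cc1` has a different core; how its core differs from the core of compound 1 is not broken down here. In this assay compound 3 gives 3030 nM, the lowest of the three numbers, and its distance to compound 2 and to compound 1 lies beyond the scatter.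

Compound 4 `Fc1ccc2[nH]c(-c3cn(-c4ccccc4)nc3-c3ccc(Cl)cc3)nc2c1` has not yet been measured. It differs from compound 3 by fluoro in place of hydrogen on an aromatic carbon. Among the measured compounds shown here, this is the same kind of change as the one from compound 1 to compound 2, but the place is not the same: there the fluoro entered on a six-membered aromatic ring of carbon only, para to a large group, whereas here it enters on a ring that is part of a fused or bridged system of two rings, meta to a fused ring and para to a fused ring. For the measured compounds named here, the only guide is that single earlier step, which stayed within the scatter. The step from compound 3 to compound 4 is therefore expected to be small, a 1.1-fold lower number from compound 3 to compound 4 (0.03 log units; within the scatter), because the earlier one was a 1.1-fold lower number from compound 1 to compound 2 (0.04 log units; within the scatter). Compound 4 is estimated at 2800 nM, expected to fall between 1200 nM and 6500 nM.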

Compound 4, half-maximal inhibitory concentration: 2830 nM
Compound 4: the middle estimate sits 1.0-fold (0.00 log units) below what was measured, within the range that was stated.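

In this assay, fluoro in place of hydrogen on an aromatic carbon again leaves the number almost where it was, with a 1.1-fold lower number from compound 3 to compound 4 (0.03 log units; within the scatter). Set beside the earlier step, the change behaves alike on the two cores: the same change on two cores in this assay, a 1.1-fold lower number (0.04 log units; within the scatter) from compound 1 to compound 2 and a 1.1-fold lower number (0.03 log units; within the scatter) from compound 3 to compound 4, 1.0-fold (0.01 log units) apart, within the scatter of two such steps. This shows that, in these two pairs, the fluoro made no difference that can be told apart from the scatter, whether it sat on a six-membered ring of carbon only or on a ring that is part of a fused system of two rings, but two pairs cannot show that it would do so at every other place or on every other core in the series.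

The compounds shown leave open whether a different group at these places, such as an amine, a methoxy group or a carboxylic acid, would move the number beyond the scatter, where fluoro does not. From the compounds shown here alone, they also do not split the difference between the core of compound 1 and the core of compound 3 into single changes, so which part of it goes with the lower numbers of compound 3 and compound 4 remains unknown.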